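A Methyl Group Added to Compound 2 at a New Place

A few compounds are considered here, and "the series" means these few. Any claim that something is new, unique, unknown or untested is made for them only; others in the source may bear on it.

Going by the values given here, in a functional assay on HeLa cells (Homo sapiens) for cytotoxicity, read by MTT assay, with a stated time of 72 h (on this read-out lower numbers stand for stronger inhibition and higher numbers for weaker inhibition), compound 2 `COC(=O)c1sc2ccccc2c1Nc1cc(OC)c(OC)c(OC)c1` gives 427 nM, the higher of the two numbers measured so far, while compound 1 `COC(=O)c1sc2cc(C)ccc2c1Nc1cc(OC)c(OC)c(OC)c1` gives 0.31 nM. Compound 3 `COC(=O)c1sc2ccc(C)cc2c1Nc1cc(OC)c(OC)c(OC)c1` is compound 2 with methyl in place of hydrogen on an aromatic carbon. Among the compounds with values here, the methyl of compound 3 stands on a different aromatic carbon from that of compound 1, so the one measured step bearing on this change is only an indirect guide: hydrogen in place of methyl gave a 1400-fold higher number from compound 1 to compound 2 (3.14 log units; beyond the scatter). That step was large, yet no measurement shows what a methyl does on this other carbon. A smaller step towards a lower number in this assay is therefore expected, and the estimate is an 11-fold lower number from compound 2 to compound 3 (1.03 log units; beyond the scatter). For compound 3 the expected value is 40 nM, with an estimated range of 2 nM to 600 nM.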

Compound 3, half-maximal inhibitory concentration: 398 nM
For compound 3 the middle estimate is 10-fold (1.00 log units) below the measured one, and the stated range covers the measured number.
By their numbers in this assay, from the lowest: compound 1; then compounds 3 and 2 (each within the scatter of the next).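

In this assay, methyl in place of hydrogen on this aromatic carbon gives a 1.1-fold lower number from compound 2 to compound 3 (0.03 log units; within the scatter), so this read-out does not separate compound 2 from compound 3. Going by these compounds alone, the earlier compounds showed only the step for a methyl on another aromatic carbon, a 1400-fold higher number from compound 1 to compound 2 (3.14 log units; beyond the scatter), and the new step shows that such a large step does not hold for every aromatic carbon of this six-membered ring. Nothing measured on these compounds accounts for the contrast between the two carbons.

From the compounds shown here alone, it remains open whether an amine or a chlorine on the carbon that carries the methyl of compound 3 would move the number beyond the scatter. Going by these compounds, it is equally open whether an ethyl on the carbon that carries the methyl of compound 1 would keep a number close to that of compound 1, which gives 0.31 nM.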